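Acetylating the ring nitrogen of a weak kinase inhibitor

The source may report more compounds than this note shows. Statements on the series, on what has been measured and on what is new or still open speak of the compounds shown alone.

Compound 1 `Cc1[nH]nc(N)c1-c1ccc(Cl)c(Cl)c1`, compound 2 `Cc1n[nH]c(N)c1-c1ccc(Cl)cc1` and compound 3 `CC(=O)n1nc(C)c(-c2ccc(Cl)cc2)c1N` share a core and were tested in an assay on Sf9 cells for inhibition of mitogen-activated protein kinase kinase kinase 14 (Homo sapiens), read by ADP-Glo, with a stated time of 60 min; on this read-out higher numbers stand for weaker inhibition and lower numbers for stronger inhibition. Compound 2 gives 61100 nM in this assay. For compound 1 this assay reports only a limit, > 100000 nM. For compound 3 it likewise reports only a limit, > 100000 nM. The difference between the cores of compound 1 and compound 2 is not broken down here. Compound 3 differs from compound 2 by acetyl in place of hydrogen on an aromatic nitrogen, and that step gives an at least 1.6-fold higher number from compound 2 to compound 3 (0.21 log units; that floor lies within the scatter). Compound 4 `CC(=O)n1nc(N)c(-c2ccc(Cl)c(Cl)c2)c1C` has not yet been measured; it differs from compound 1 by acetyl in place of hydrogen on an aromatic nitrogen. This is the same kind of change as from compound 2 to compound 3, but the place differs: in compound 2 the nitrogen is next to the ring atom that bears an amino group and two ring bonds from the ring atom that bears a group of 7 heavy atoms, whereas in compound 1 it is next to the ring atom that bears a methyl group and two ring bonds from the ring atom that bears a group of 8 heavy atoms. The expected step from compound 1 to compound 4 in this assay is a step that the limit leaves unreadable from compound 1 to compound 4, because compound 1 already stands at the limit of > 100000 nM in this assay, at which 2 of the 3 values shown sit. Compound 4 is therefore expected to give 150000 nM, with a range from 50000 nM to 500000 nM.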

Compound 4, half-maximal inhibitory concentration: > 100000 nM
Compound 4 gave a limit, no number; the forecaster's own chance of this, stated with the estimate: 85%; the middle value lies beyond the limit too.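

No step can be read from compound 1 to compound 4 in this assay, since both compounds stand at the same limit: the limit of > 100000 nM in this assay, at which 3 of the 4 values shown sit.

The compounds shown leave open whether acetyl in place of hydrogen on an aromatic nitrogen changes inhibition at all on the core of compound 1, and by how much.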